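Compound 4 in a series that stays at the limit

A few compounds are considered here, and "the series" means these few. Any claim that something is new, unique, unknown or untested is made for them only; others in the source may bear on it.

Measured in an ADME assay on HEK293 cells (Homo sapiens) for cytotoxicity, read by luminescence, with a stated time of 72 h; on this read-out higher numbers stand for an effect only at larger amounts of compound and lower numbers for an effect already at smaller amounts:
- Compound 1 `CCOC(=O)c1c(-c2cccc(-c3ccccc3)c2)[nH]c2cc(OC)c(F)cc2c1=O`: > 22000 nM (a limit)
- Compound 2 `CCOC(=O)c1c(-c2cccc(F)c2)[nH]c2cc(OC)c(F)cc2c1=O`: > 22000 nM (a limit)
- Compound 3 `CCOC(=O)c1c(-c2cccc(Br)c2)[nH]c2cc(OC)c(F)cc2c1=O`: > 22000 nM (a limit)

Compound 3 stands at a limit and not at a number, with > 22000 nM. The whole set rests on (the limit of > 22000 nM in this assay, at which 3 of the 3 values shown sit).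

The next structure is compound 4 `CCOC(=O)c1c(-c2cccc(Oc3c(C)cccc3C)c2)[nH]c2cc(OC)c(F)cc2c1=O`, with the change (2,6-dimethylphenoxy in place of bromo on an aromatic carbon). In words, this is 2,6-dimethylphenoxy in place of bromo on an aromatic carbon, meta to a large group.

Going by the values given here, three measured steps bear on this change: a step that the two limits leave unreadable from compound 1 to compound 3, a step that the two limits leave unreadable from compound 2 to compound 3 and a step that the two limits leave unreadable from compound 1 to compound 2. None has a readable size, so none gives a direction. Compound 1 carries phenyl where compound 3 carries bromo. The value of compound 1 is also a limit, with > 22000 nM.

Fluoro, bromo and phenyl thus all end at the same limit, and none of the three compounds goes against this. Among the compounds with values here, the 2,6-dimethylphenoxy group itself has no measurement yet. No clear step in either direction is expected in this assay, and a further limit is the likeliest report.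

The expected step is a number no higher from compound 3 to compound 4 (the limit leaves the size open).

For compound 4 the estimate is 22000 nM, with an expected range of 9000 nM to 40000 nM.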

Compound 4, half-maximal effective concentration: > 22000 nM
Compound 4: no number, only a limit; the forecaster's own chance of this, stated with the estimate: 75%; the middle value lies on the limit itself.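

In this assay, going by these compounds alone, compound 4 gives only a limit, as do compound 1, compound 2 and compound 3, so no step to compound 4 can be read. The compounds shown leave open where the half-maximal effective concentration of any of the four lies, and whether fluoro, bromo, phenyl or 2,6-dimethylphenoxy shifts it.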